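Replacing a sulfonylpyridinylmethyl group with a trifluoromethylphenyl ring

A few compounds are considered here, and "the series" means these few. Any claim that something is new, unique, unknown or untested is made for them only; others in the source may bear on it.

Compound 1 `CCS(=O)(=O)c1ccc(CN(CC(C)C)S(=O)(=O)c2ccc3c(c2)C(O)CC(C2CCOCC2)O3)nc1` gives the lowest value of the three measured compounds in a physicochemical assay for lipophilicity, at pH 7.4 (a lower number here means a more polar compound, a higher number a more lipophilic compound), at 1.42. Compound 2 `CCc1ccc(N(CC(C)C)S(=O)(=O)c2ccc3c(c2)CCC(C2CCOCC2)O3)cc1` gives 5.38 in this assay, and compound 3 `CCc1ccc(N(CC(C)C)S(=O)(=O)c2ccc(OCC3CCOCC3)c3c2CCC3O)cc1` gives 4.55; each stands well beyond the scatter above compound 1. Compound 4 `CC(C)CN(c1ccccc1C(F)(F)F)S(=O)(=O)c1ccc2c(c1)C(O)CC(C1CCOCC1)O2` is not yet measured. It differs from compound 1 in one place: 2-(trifluoromethyl)phenyl in place of (5-(ethylsulfonyl)pyridin-2-yl)methyl on a sulfonamide nitrogen. Because compound 2 gives 5.38 and compound 3 gives 4.55 with a simpler aryl group on the sulfonamide nitrogen, the change is expected to raise the reading by a large step, a number 2.78 log units higher from compound 1 to compound 4 (beyond the scatter). Compound 4 is therefore estimated at 4.2 in this assay, within a range from 3.5 to 4.9.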

Compound 4, distribution coefficient: 4.14
Beside the measured number, compound 4's estimate is 0.06 log units above it; low and high end bracket the measured number.
By their numbers in this assay, from the lowest: compound 1; then compound 4; then compound 3; then compound 2.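

On the sulfonamide nitrogen, with the rest of the molecule unchanged, this assay moves by a number 2.72 log units higher from compound 1 to compound 4 (beyond the scatter) when 2-(trifluoromethyl)phenyl enters in place of (5-(ethylsulfonyl)pyridin-2-yl)methyl. This is the first single-place change shown, and it establishes that this position alone can produce a large step in the reading. No available evidence accounts for the size of the step. The compounds shown leave open which part of the exchanged group carries the step, and how an amine or a carboxylic acid on the aryl ring at this position would read.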